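Changing the aryl group on the amine nitrogen

The source may hold more compounds than are shown below. What is called first, only, known or untested is meant among the compounds shown, and "the series" means these compounds.

Among the compounds with values here, in a functional assay on MCF7 cells (Homo sapiens) for cytotoxicity, read by MTT assay, with a stated time of 48 h (on this read-out higher numbers stand for weaker inhibition and lower numbers for stronger inhibition), compound 1 `COc1ccc(N/C(CCNC2=CC(=O)c3ccccc3C2=O)=N\S(=O)(=O)c2ccc(C)cc2)cc1` gives 6030 nM, the lowest of the two numbers measured so far. Compound 2 `Cc1ccc(S(=O)(=O)/N=C(/CCNC2=CC(=O)c3ccccc3C2=O)Nc2ccccc2I)cc1` gives 15500 nM in this assay, and the step of a 2.6-fold higher number from compound 1 to compound 2 (0.41 log units; beyond the scatter) came with 2-iodophenyl in place of 4-methoxyphenyl on an amine nitrogen. Compound 3 `Cc1ccc(S(=O)(=O)/N=C(/CCNC2=CC(=O)c3ccccc3C2=O)Nc2cccc(C(F)(F)F)c2)cc1` differs from compound 1 in the same place: 3-(trifluoromethyl)phenyl in place of 4-methoxyphenyl on an amine nitrogen. Within the data shown here, the only measured step that bears on this change is the one from compound 1 to compound 2, which was modest. Since the change in compound 3 is also a swap of the aryl group on that amine nitrogen, a step of similar size and direction is expected, namely a 2.0-fold higher number from compound 1 to compound 3 (0.30 log units; within the scatter). Compound 3 is therefore estimated at 12000 nM in this assay, with a range from 5000 nM to 30000 nM.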

Compound 3, half-maximal inhibitory concentration: 89100 nM
Compound 3: the middle estimate sits 7.4-fold (0.87 log units) below what was measured; measured number above the stated range.
By their numbers in this assay, from the lowest: compound 1; then compound 2; then compound 3.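

In this assay, within the data shown here, the aryl group on this amine nitrogen turns out to carry far more weight than the first pair of compounds suggested: 3-(trifluoromethyl)phenyl in place of 4-methoxyphenyl gives a 15-fold higher number from compound 1 to compound 3 (1.17 log units; beyond the scatter). The two replacements also do not land at the same level, since 3-(trifluoromethyl)phenyl in place of 2-iodophenyl gives a 5.7-fold higher number from compound 2 to compound 3 (0.76 log units; beyond the scatter), so the number depends on which aryl group enters and not merely on 4-methoxyphenyl leaving. No measurement at hand accounts for this spread.

The three aryl groups differ both in their substituent and in where it sits, so these two contributions cannot yet be separated. An unsubstituted phenyl group or a 4-(trifluoromethyl)phenyl group on the same nitrogen would help to tell them apart.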